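Shifting the aryl substituent on a shared bicyclic core

This account rests on a few compounds, and the source may have more. Where it says the series, first, only, none or still open, it means among the compounds named here.

Compound 1: `O=Cc1ccc(-c2cn3ccnc3c(-c3ccc4ncn(C5CCCCC5)c4c3)n2)cc1` — 37.8%
Compound 2: `c1ccc2c(-c3cn4ccnc4c(-c4ccc5ncn(C6CCCCC6)c5c4)n3)cccc2c1` — 3.61%
Compound 3: `CCc1ccc(-c2cn3ccnc3c(-c3ccc4ncn(Cc5ccccc5)c4c3)n2)cc1` — 42%

Of the compounds shown here, three sharing one core have been measured in a functional assay on NCI-H460 cells (Homo sapiens) for inhibition, read by sulforhodamine B assay, with a stated time of 48 h, tested at 10 uM; on this read-out higher numbers stand for more inhibition at the one concentration tested (going by the name of the read-out) and lower numbers for less inhibition. Compound 3 stands highest of the three numbers, but its gap to compound 1 is within the scatter, so the two cannot be ranked against each other; only compound 2 sits clearly apart, far below both.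

Among the measured compounds shown here, the one measured step is a number 34.2 percentage points lower from compound 1 to compound 2 (beyond the scatter). It shows that the number in this assay can move a long way when the aryl group at this position on the core is exchanged, though it involves a different pair of groups than the step now in question.

Compound 4 is `Cc1cccc(-c2cn3ccnc3c(-c3ccc4ncn(Cc5ccccc5)c4c3)n2)c1`. It differs from compound 3 by 3-methylphenyl in place of 4-ethylphenyl on an aromatic carbon. For the measured compounds named here, no measured pair shows this particular exchange, and the one step available concerns much larger groups, so it gives only a loose guide. Given that compound 3 gives 42%, a change no larger than the scatter is expected, and compound 4 is estimated at 38%, with a range from 20% to 56%. The expected step is therefore a number 4 percentage points lower from compound 3 to compound 4 (within the scatter).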

Compound 4, a percentage reported as inhibition, at one concentration (the size of the read-out at that concentration, not a potency): 10.1%
Beside the measured number, compound 4's estimate is 27.9 percentage points above it, outside the stated range (below it).
By their numbers in this assay, from the lowest: compounds 2 and 4 (each within the scatter of the next); then compounds 1 and 3 (each within the scatter of the next).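

In this assay the exchange of 4-ethylphenyl for 3-methylphenyl gives a number 31.9 percentage points lower from compound 3 to compound 4 (beyond the scatter), with the rest of compound 3 left unchanged. The earlier step, a number 34.2 percentage points lower from compound 1 to compound 2 (beyond the scatter), replaced 4-formylphenyl with the larger naphthalen-1-yl, whereas this one exchanges two phenyl groups of 8 and 7 heavy atoms, both made of carbon only and neither carrying a hydrogen-bond donor or acceptor, so a large drop at this position does not require a bulky new group or the loss of a carbonyl. This single change alters both the length of the alkyl chain and its place on the phenyl ring, and nothing available explains the drop or says which of the two alterations carries it.

The compounds shown leave open how the number would respond to 4-methylphenyl or 3-ethylphenyl, either of which would separate the chain length from the place on the ring. They also leave open whether a group of another kind on the phenyl ring, such as an amine or a carboxylic acid, would hold the number near that of compound 3 or lower it towards that of compound 4.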